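Trimming a Chain in a Cytotoxicity Series

The source may report more compounds than this note shows. Statements on the series, on what has been measured and on what is new or still open speak of the compounds shown alone.

Compound 2 `CCCCCCCCCCCO[C@@H]1[C@@H](N)[C@@H](O[C@H]2[C@H](O)[C@@H](O)[C@H](N)C[C@@H]2N)O[C@H](CN)[C@H]1O` is the reference point here. Within the data shown here, in an ADME assay on J774 cells (Mus musculus) for cytotoxicity, read by MTT assay, with a stated time of 24 h, tested at 30 uM (a lower number here means a stronger effect, a higher number a weaker effect of the compound at the concentration tested), compound 2 gives 77.1%, the highest of the three numbers measured so far, meaning the weakest effect on the cells at the tested concentration. Compound 3 `NC[C@H]1O[C@H](O[C@H]2[C@H](O)[C@@H](O)[C@H](N)C[C@@H]2N)[C@H](N)[C@@H](OCCCc2ccc3ccccc3c2)[C@@H]1OCCCc1ccc2ccccc2c1` comes nearest, giving 66.9% in this assay. Compound 1 `CCCCCCCCCCCO[C@@H]1[C@@H](N)[C@@H](O[C@H]2[C@H](O)[C@@H](OCCCCCCC)[C@H](N)C[C@@H]2N)O[C@H](CN)[C@H]1O` stands furthest away with 39.1%. Among the measured compounds shown here, the only step between compounds that differ in a single place runs a number 38 percentage points higher from compound 1 to compound 2 (beyond the scatter), so losing a chain on an oxygen left the cells markedly less affected.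

Compound 4 `CCCCCCCO[C@@H]1[C@@H](N)[C@@H](O[C@H]2[C@H](O)[C@@H](O)[C@H](N)C[C@@H]2N)O[C@H](CN)[C@H]1O` has not yet been measured. It differs from compound 2 by hydrogen in place of butyl on a saturated chain carbon, seven bonds along the chain from an oxygen on a saturated carbon; put simply, the remaining long chain is cut shorter. For the measured compounds named here, the step from compound 1 to compound 2 is the sole measured guide, and it points toward a weaker effect when chain is lost, although a smaller piece leaves here. Because compound 2 already gives 77.1%, the room upward is limited. A modest rise is expected, a number 8.9 percentage points higher from compound 2 to compound 4 (within the scatter). Compound 4 is therefore estimated at 86%, within a range from 72% to 100%.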

Compound 4, a percentage reported as activity, at one concentration (the size of the read-out at that concentration, not a potency): 70.2%
For compound 4 the middle estimate is 15.8 percentage points above the measured one; the whole stated range lies above it.
By their numbers in this assay, from the lowest: compound 1; then compounds 3, 4 and 2 (each within the scatter of the next, the first and the last beyond it).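

Trimming this chain, with hydrogen in place of butyl seven bonds along from the oxygen, gives a number 6.9 percentage points lower from compound 2 to compound 4 (within the scatter) in this assay, so this change cannot be told apart from repeat-to-repeat variation. The large rise seen for loss of heptyl, a number 38 percentage points higher from compound 1 to compound 2 (beyond the scatter), therefore does not carry over to this shortening of the remaining chain, and compound 4, with its shorter chain, reads much like compound 2 in this assay. No evidence here explains why the two chain changes differ.

What the compounds shown leave open is how far this chain can be cut before the read-out moves. From the compounds shown here alone, it also remains open whether a chain ending in an amine or a carboxylic acid would behave the same way.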